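The source may hold more compounds than are shown below. What is called first, only, known or untested is meant among the compounds shown, and "the series" means these compounds.

Measured in an ADME assay on HT-29 cells (Homo sapiens) for inhibition, read by trypan blue exclusion, with a stated time of 72 h; a lower number here means a stronger inhibitor of growth, a higher number a weaker inhibitor of growth:
compound 1 `O=C(/C=C/c1ccccc1)c1cccc([N+](=O)[O-])c1` gives 9000 nM
compound 2 `COc1cccc(C(=O)/C=C/c2ccccc2)c1` gives 14700 nM
compound 3 `COc1ccccc1C(=O)/C=C/c1ccccc1` gives 14800 nM

Compound 4 `O=C(/C=C/c1ccccc1)c1ccccc1[N+](=O)[O-]` has not been measured. From compound 2 to compound 1 the change is nitro in place of methoxy on an aromatic carbon; it gave a 1.6-fold lower number from compound 2 to compound 1 (0.21 log units; within the scatter). From compound 3 to compound 4 the change is nitro in place of methoxy on an aromatic carbon. The place is not the same: in the first case the nitro stands meta to a large group, in the second ortho to a large group, so this is the same kind of change, not the same change. How the cores of compound 2 and compound 3 differ is not broken down here; their two values lie within the scatter of each other. The step expected in this assay is a 1.6-fold lower number from compound 3 to compound 4 (0.19 log units; within the scatter), resting on the earlier case because a 1.6-fold lower number from compound 2 to compound 1 (0.21 log units; within the scatter) stayed within the scatter. Compound 4 is therefore estimated at 9500 nM, expected between 4500 nM and 20000 nM.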

Compound 4, concentration for 50% growth inhibition: 8300 nM
Compound 4: the middle estimate sits 1.1-fold (0.06 log units) above what was measured; the measured number falls inside the stated range.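

In this assay, nitro in place of methoxy on an aromatic carbon gives a 1.8-fold lower number from compound 3 to compound 4 (0.25 log units; within the scatter), and the steps on the two cores do not differ: the same change on two cores in this assay, a 1.6-fold lower number (0.21 log units; within the scatter) from compound 2 to compound 1 and a 1.8-fold lower number (0.25 log units; within the scatter) from compound 3 to compound 4, 1.1-fold (0.04 log units) apart, within the scatter of two such steps. The change therefore carries across these two cores without a detectable difference, including to the core where the nitro stands ortho to a large group. Neither step lies beyond the scatter, however, so these pairs do not establish that nitro differs from methoxy on either core, and two pairs set no rule for the wider series.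

As far as these compounds go, it remains open whether an amine, a carboxylic acid or a trifluoromethyl group on the same aromatic carbon would give a step beyond the scatter.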